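Cytotoxicity notes on the benzazepine series, compound 3 pending

A few compounds are considered here, and "the series" means these few. Any claim that something is new, unique, unknown or untested is made for them only; others in the source may bear on it.

Compound 1 `COc1cccc2c1CN(C)C[C@@H]2O`: > 100000 nM
Compound 2 `CN1Cc2c(OCc3ccccc3)cccc2[C@@H](O)C1`: > 100000 nM

In an ADME assay on Vero cells (Chlorocebus sabaeus) for cytotoxicity, read by sulforhodamine B assay, with a stated time of 72 h (a higher number here means a weaker inhibitor, a lower number a stronger inhibitor), compound 1 reaches only the assay limit, > 100000 nM. In this assay compound 2 likewise stops at the limit, > 100000 nM. Among the compounds with values here, the one measured step, a step that the two limits leave unreadable from compound 1 to compound 2, cannot be read, since both ends sit at the same limit (the limit of > 100000 nM in this assay, at which 2 of the 2 values shown sit). Compound 3 `CN1Cc2c(OCCC3CCCCC3)cccc2[C@@H](O)C1` carries the change (cyclohexylmethyl in place of phenyl on a saturated chain carbon bound to an oxygen on an aromatic ring). Within the data shown here, no measured step bears on this change; with both neighbours at the limit, compound 3 is expected to remain there as well, the expected step being a number no higher from compound 2 to compound 3 (the limit leaves the size open). The estimate for compound 3 is 100000 nM, ranging from 40000 nM to 300000 nM.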

Compound 3, half-maximal inhibitory concentration: 62700 nM
For compound 3 the middle estimate is 1.6-fold (0.20 log units) above the measured one, and the stated range covers the measured number.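

Within the data shown here, compound 3 is the first compound here to give a number rather than a limit in this assay, so a change on a saturated chain carbon bound to an oxygen on an aromatic ring can register in this read-out. Cyclohexylmethyl in place of phenyl gives an at least 1.5-fold lower number from compound 2 to compound 3 (0.20 log units; that floor lies within the scatter), and cyclohexylmethyl in place of hydrogen gives an at least 1.5-fold lower number from compound 1 to compound 3 (0.20 log units; that floor lies within the scatter). Both steps are floors, and their full size stays unread: the limit of > 100000 nM in this assay, at which 2 of the 3 values shown sit.

Open, as far as these compounds go, is whether a longer chain ending in cyclohexyl would give a lower number. Also open, from the compounds shown here alone, is how an amine or a carboxylic acid would read at this place.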